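A few compounds are considered here, and "the series" means these few. Any claim that something is new, unique, unknown or untested is made for them only; others in the source may bear on it.

Measured so far in a functional assay on HL-60 cells (Homo sapiens) for cytotoxicity, read by WST assay, with a stated time of 48 h; a lower number here means that less compound is needed, a higher number that more compound is needed for the effect:

- Compound 1 `CCc1ccc(C[C@H]2COC(=O)[C@@H]2Cc2ccc(Cl)c(Cl)c2)cc1` gives 16000 nM
- Compound 2 `Oc1ccc(C[C@H]2COC[C@@H]2Cc2ccc(Cl)c(Cl)c2)cc1` gives 31000 nM
- Compound 3 `COc1ccc(C[C@H]2COC[C@@H]2Cc2ccc(Cl)c(Cl)c2)cc1` gives 39000 nM

Compound 3 stands at the upper end of these three numbers. It lies within the scatter of compound 2, and only compound 1 lies lower by more than the scatter.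

The next compound, compound 4 `CCc1ccc(C[C@H]2COC[C@@H]2Cc2ccc(Cl)c(Cl)c2)cc1`, differs from compound 3 in one place: ethyl in place of methoxy on an aromatic carbon, para to a large group (ethyl in place of methoxy on an aromatic carbon). Going by the values given here, no measured step makes exactly this exchange. The closest is a 1.3-fold higher number from compound 2 to compound 3 (0.10 log units; within the scatter), where methyl replaces hydrogen on the oxygen at the same ring position. That change left the number within the scatter, which suggests a small effect at this position but does not prove it for an ethyl group. Compound 1 also bears ethyl, on a core of its own, and its 16000 nM gives a weak hint toward a somewhat lower number.

In this assay no step beyond the scatter is therefore expected, only a slight drift downward. The estimated step is a 1.4-fold lower number from compound 3 to compound 4 (0.14 log units; within the scatter) and remains an expectation until measured. The estimate for compound 4 is 28000 nM, with an expected range from 12000 nM to 60000 nM.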

Compound 4, half-maximal effective concentration: 26000 nM
Estimate against measurement, compound 4: 1.1-fold (0.03 log units) above; measured number inside the range.
By their numbers in this assay, from the lowest: compounds 1, 4, 2 and 3 (each within the scatter of the next, the first and the last beyond it).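

In this assay the exchange of methoxy for ethyl on the aromatic carbon gives a 1.5-fold lower number from compound 3 to compound 4 (0.18 log units; within the scatter) and the exchange of hydroxy for ethyl gives a 1.2-fold lower number from compound 2 to compound 4 (0.08 log units; within the scatter), so all three groups at this position on the shared core now lie within the scatter of one another. Going by these compounds alone, until now the only comparison at this position was between two groups that both place an oxygen on the ring, whereas ethyl has no oxygen and its hydrogen-bond acceptor count is zero against one for methoxy, and even this exchange does not take the number beyond the scatter. Nothing available explains why the number holds across these groups.

Going by these compounds, whether an amine, a carboxylic acid or a longer chain at this position would give a step beyond the scatter stays open. Also open is whether the same picture holds on the core of compound 1, which carries a carbonyl, since ethyl is the only group shown at this position on that core.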